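This account rests on a few compounds, and the source may have more. Where it says the series, first, only, none or still open, it means among the compounds named here.

Measured so far in a toxicity assay on NIH3T3 cells (Mus musculus) for cytotoxicity, read by resazurin assay; on this read-out higher numbers stand for an effect only at larger amounts of compound and lower numbers for an effect already at smaller amounts:
compound 1 `COC(=O)c1ccc(NCc2cncn2Cc2ccc(N)cc2)cc1-c1ccccc1` — limit of the assay, > 10000 nM
compound 2 `COC(=O)c1ccc(NCc2cncn2Cc2cccc(Br)c2)cc1-c1ccccc1` — limit of the assay, > 10000 nM
compound 3 `COC(=O)c1ccc(NCc2cncn2Cc2ccc(-c3ccccc3)cc2)cc1-c1ccccc1` — limit of the assay, > 1000 nM

None of the three values is a number. Compound 3 sits at the limit of > 1000 nM in this assay, at which 1 of the 3 values shown sits. Compound 1 sits at the limit of > 10000 nM in this assay, at which 2 of the 3 values shown sit. Compound 2 sits at that same limit. Compound 3 therefore stands only at a limit, as do both of the others, and no order among the three can be read from this assay.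

The next compound is compound 4 `COC(=O)c1ccc(NCc2cncn2Cc2ccccc2C#N)cc1-c1ccccc1`. Its change from compound 3 is 2-cyanophenyl in place of 4-phenylphenyl on a saturated chain carbon bound to an aromatic nitrogen. The measured steps at the same place are a step that the two limits leave unreadable from compound 2 to compound 3 and a step that the two limits leave unreadable from compound 1 to compound 2; the remaining step, a step that the two limits leave unreadable from compound 1 to compound 3, changes a different place. All three are left unreadable by the two limits, so none of them yields a size or a direction for the present change. Among the compounds with values here, what the measured set shows is only that every compound so far reaches no readable number in this assay.

The expectation for compound 4 is accordingly a step that the limit leaves unreadable from compound 3 to compound 4, meaning no change beyond the scatter, with a further limit the most likely outcome. The value expected for compound 4 in this assay is 20000 nM, in the range 5000 nM to 100000 nM.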

Compound 4, half-maximal effective concentration: 25000 nM
Compound 4: middle estimate off by 1.3-fold (0.10 log units), on the low side, within the range that was stated.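

In this assay, within the data shown here, compound 1, compound 2 and compound 3 stand only at limits of the assay, and no step from any of them to compound 4 can be read. The compounds shown leave open whether 2-cyanophenyl, 4-phenylphenyl, 3-bromophenyl and 4-aminophenyl differ at all in their effect on these cells.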